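The source may report more compounds than this note shows. Statements on the series, on what has been measured and on what is new or still open speak of the compounds shown alone.

Going by the values given here, compound 1 `CSc1cc(C)nc(SC)c1NC(=O)N(Cc1ccccc1)Cc1cccc(-c2cc[nH]n2)c1` is, in a functional assay on a cell-free system (plasma) with sterol O-acyltransferase, Soat (Rattus norvegicus) as the target (a lower number here means that less compound is needed, a higher number that more compound is needed for the effect), the one compound with a number: compound 1 gives 0.046 mg/kg. Compound 2 `COc1ccccc1CN(Cc1cccc(-c2cc[nH]n2)c1)C(=O)Nc1c(SC)cc(C)nc1SC` reaches only a limit there; compound 2 gives > 0.1 mg/kg, a limit of the assay and not a number. Among the compounds with values here, the sole measured step, an at least 2.1-fold higher number from compound 1 to compound 2 (0.33 log units; beyond the scatter), concerns a methoxy in place of hydrogen on an aromatic carbon, the upper side of that step being (the limit of > 0.1 mg/kg in this assay, at which 1 of the 2 values shown sits). Compound 3 `CSc1cc(C)nc(SC)c1NC(=O)N(Cc1ccccc1)Cc1ccc(-c2cc[nH]n2)cc1` differs from compound 1 in another way: 4-(1H-pyrazol-3-yl)phenyl in place of 3-(1H-pyrazol-3-yl)phenyl on a saturated chain carbon bound to an amide-type nitrogen. Within the data shown here, no measured step concerns this rearrangement of the same atoms, and the methoxy step gives no guide to its direction. A step beyond the scatter in this assay is possible either way, and a somewhat higher number is taken as the more likely outcome. Compound 3 is expected to give 0.07 mg/kg, between 0.025 mg/kg and 0.2 mg/kg. The step this estimate means from compound 1 to compound 3 is a 1.5-fold higher number from compound 1 to compound 3 (0.18 log units; within the scatter).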

Compound 3, dose for half-maximal effect: < 0.32 mg/kg
Compound 3: no number, only a limit (the forecaster's own chance of this, stated with the estimate: 25%); the middle value does not contradict the limit.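

In this assay compound 3 gives < 0.32 mg/kg, which is a limit of the assay and not a number, and the step from compound 1 to compound 3 cannot be read. The compounds shown leave open whether 4-(1H-pyrazol-3-yl)phenyl in place of 3-(1H-pyrazol-3-yl)phenyl raises, lowers or leaves unchanged the number in this assay.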